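The source may hold more compounds than are shown below. What is called first, only, known or untested is meant among the compounds shown, and "the series" means these compounds.

Of the compounds shown here, three built on one shared core have so far been tested in an ADME assay on L6 cells (Rattus norvegicus) for cytotoxicity, read by resazurin assay, with a stated time of 72 h; on this read-out higher numbers stand for weaker inhibition and lower numbers for stronger inhibition. In this test compound 1 `O=[N+]([O-])c1cn2c(n1)OC[C@H](OCc1ccc(-c3ccc(OC(F)(F)F)cc3Cl)cc1)C2` gives 25000 nM, compound 2 `O=[N+]([O-])c1cn2c(n1)OC[C@@H](OCc1ccc(-c3ccc(OC(F)(F)F)cc3Cl)cc1)C2` gives 19000 nM, and compound 3 `O=[N+]([O-])c1cn2c(n1)OC[C@H](OCc1ccc(-c3ccc(C(F)(F)F)cc3Cl)cc1)C2` gives 29000 nM. These three numbers all lie within the usual scatter of one another, so compound 3 stands level with the other two, and all that can be said is that they share one range.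

The next compound, compound 4 `O=[N+]([O-])c1cn2c(n1)OC[C@@H](OCc1ccc(-c3ccc(C(F)(F)F)cc3Cl)cc1)C2`, has a single difference from compound 3: the two compounds have the same atoms and bonds and differ only in configuration as drawn: 1 of 1 stereo elements differ; a stereocentre at a saturated ring carbon is drawn R in compound 3 and S in compound 4. Nothing leaves and nothing enters, so the two have the same atoms and bonds.

The most direct guide is the same kind of change in the other pair, (the fact that compounds 1 and 2 differ only in the configuration as drawn), which gave a 1.3-fold lower number from compound 1 to compound 2 (0.12 log units; within the scatter). The remaining measured step, a 1.2-fold higher number from compound 1 to compound 3 (0.06 log units; within the scatter), has trifluoromethyl in place of trifluoromethoxy and shows that the two pairs start from matching values. Both steps are small, so no step beyond the scatter is expected in this assay, only a possible slight drift in the direction seen for compound 2. The expected step is a 1.3-fold lower number from compound 3 to compound 4 (0.10 log units; within the scatter). Compound 4 is estimated at 23000 nM, with an expected range of 13000 nM to 38000 nM.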

Compound 4, half-maximal inhibitory concentration: 34000 nM
The estimate for compound 4 lay 1.5-fold (0.17 log units) below the measured number, and the stated range covers the measured number.
By their numbers in this assay, from the lowest: compounds 2, 1, 3 and 4 (each within the scatter of the next).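

In this assay, inverting the stereocentre at the saturated ring carbon with trifluoromethyl in place gives a 1.2-fold higher number from compound 3 to compound 4 (0.07 log units; within the scatter), so this inversion has now been read with two different groups and has stayed within the scatter both times. The swap of trifluoromethoxy for trifluoromethyl can now also be read on the second configuration, where it gives a 1.8-fold higher number from compound 2 to compound 4 (0.25 log units; within the scatter), and the two readings of that swap agree: the same change on two cores in this assay, a 1.2-fold higher number (0.06 log units; within the scatter) from compound 1 to compound 3 and a 1.8-fold higher number (0.25 log units; within the scatter) from compound 2 to compound 4, 1.5-fold (0.19 log units) apart, within the scatter of two such steps. Neither the configuration at this carbon nor the choice between these two fluorinated groups has therefore produced a step beyond the scatter, and all four compounds remain in one range in this test of toxicity to rat cells.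

The compounds shown leave open whether a group of a different kind in the place of trifluoromethyl, such as an amine or a carboxylic acid, would produce a step beyond the scatter. They also leave open whether the two configurations would differ in a test other than this one, since a difference that does not appear here could still appear elsewhere.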